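Ethyl replaces cyclohexyl on the triazole-thione nitrogen

This account rests on a few compounds, and the source may have more. Where it says the series, first, only, none or still open, it means among the compounds named here.

Compound 2 `Oc1ccc(-c2ccc(F)cc2F)cc1-c1n[nH]c(=S)n1C1CCCCC1` gives 64.4% in a functional assay on the whole organism (strain BALB/c) for inhibition, with Mus musculus as the target, read by paw edema, with a stated time of 4 h, at a dose of 50 mg/kg by the oral route; on this read-out higher numbers stand for more inhibition at the one dose given (going by the name of the read-out) and lower numbers for less inhibition; compound 1 `Cn1c(-c2cc(-c3ccc(F)cc3F)ccc2O)n[nH]c1=S` gives 56.9%, and the two stand within the scatter of each other, as the step of a number 7.5 percentage points higher from compound 1 to compound 2 (within the scatter) shows. Compound 3 `CCn1c(-c2cc(-c3ccc(F)cc3F)ccc2O)n[nH]c1=S` differs from compound 2 by ethyl in place of cyclohexyl on an aromatic nitrogen. Going by the values given here, the only step that bears on this change is the one from compound 1 to compound 2, which stayed within the scatter, so no step beyond the scatter is expected here either; the estimated step is a number 5.4 percentage points lower from compound 2 to compound 3 (within the scatter). Compound 3 is therefore expected to give about 59%, with a range from 46% to 72%.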

Compound 3, a percentage reported as inhibition, in the whole organism at one dose (the size of the read-out at that dose, not a potency): 46.2%
Estimate against measurement, compound 3: 12.8 percentage points above; low and high end bracket the measured number.
By their numbers in this assay, from the lowest: compound 3; then compounds 1 and 2 (each within the scatter of the next).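

In this assay, going by these compounds alone, ethyl gives the first steps beyond the scatter at this aromatic nitrogen: a number 18.2 percentage points lower from compound 2 to compound 3 (beyond the scatter) and a number 10.7 percentage points lower from compound 1 to compound 3 (beyond the scatter). The read-out does not follow the heavy-atom count of the group: methyl and cyclohexyl stand within the scatter of each other, while ethyl, with a count between theirs, reads lower than both. Nothing available explains this result. As far as these compounds go, whether a propyl chain, an isopropyl group or a cyclopentyl ring at this nitrogen would read nearer to ethyl or to cyclohexyl remains open.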